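This account rests on a few compounds, and the source may have more. Where it says the series, first, only, none or still open, it means among the compounds named here.

Compound 1 `O=C1Nc2ccc(S(=O)(=O)N3CCOCC3)cc2/C1=N/c1cccc(C(F)(F)F)c1`: 14300 nM
Compound 2 `O=C1Nc2ccc(S(=O)(=O)N3CCOCC3)cc2/C1=N/NC(=O)c1ccccc1`: 18100 nM
Compound 3 `O=C1Nc2ccc(S(=O)(=O)N3CCOCC3)cc2/C1=N/Nc1ccccc1`: 15600 nM

These three compounds share one core and were tested in a functional assay on HepG2 cells (Homo sapiens) for cytotoxicity, read by sulforhodamine B assay, with a stated time of 24 h; on this read-out lower numbers stand for stronger inhibition and higher numbers for weaker inhibition. Compound 3 has no clear place in their order. The data show a 1.1-fold higher number from compound 1 to compound 3 (0.04 log units; within the scatter) and a 1.2-fold lower number from compound 2 to compound 3 (0.06 log units; within the scatter), so it cannot be told apart from either of the others.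

The next compound, compound 4 `O=C1Nc2ccc(S(=O)(=O)N3CCOCC3)cc2/C1=N/c1ccc(Cl)cc1`, keeps that core and changes one group: 4-chlorophenyl in place of anilino on a double-bonded nitrogen. In words, 4-chlorophenyl stands in place of anilino on a double-bonded nitrogen. Compound 4 thus carries a substituted phenyl there, as compound 1 does. The nearest measured change is anilino in place of 3-(trifluoromethyl)phenyl, which gave a 1.1-fold higher number from compound 1 to compound 3 (0.04 log units; within the scatter). Benzamido in place of that same group gave a 1.3-fold higher number from compound 1 to compound 2 (0.10 log units; within the scatter). Among the compounds with values here, all the exchanges measured so far stayed small, and no compound here goes against that. None of them involves chlorine, however, so the data cannot show what this particular group does. In this assay, no step beyond the scatter is therefore expected, and no direction can be favoured. The expected step is a 1.0-fold lower number from compound 3 to compound 4 (0.02 log units; within the scatter). For compound 4 the estimated value is 15000 nM, with an expected range from 7500 nM to 30000 nM.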

Compound 4, half-maximal inhibitory concentration: 11800 nM
Beside the measured number, compound 4's estimate is 1.3-fold (0.10 log units) above it; measured number inside the range.
By their numbers in this assay, from the lowest: compounds 4, 1, 3 and 2 (each within the scatter of the next).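

In this assay the exchange of anilino for 4-chlorophenyl on a double-bonded nitrogen gives a 1.3-fold lower number from compound 3 to compound 4 (0.12 log units; within the scatter) and the exchange of benzamido for the same group gives a 1.5-fold lower number from compound 2 to compound 4 (0.19 log units; within the scatter) while the exchange of 3-(trifluoromethyl)phenyl for it gives a 1.2-fold lower number from compound 1 to compound 4 (0.08 log units; within the scatter) in this series. Within the data shown here, a ring carrying chlorine, which no earlier compound had, therefore joins the other groups at this position without any step beyond the scatter, so all four compounds remain indistinguishable here. This also holds for the exchange from anilino, with its 1 hydrogen-bond donor and 1 hydrogen-bond acceptor, to 4-chlorophenyl, which has neither, and nothing available explains why these steps stay so small.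

Every group shown at this position contains a six-membered aromatic ring of carbon only, so it remains open whether a longer alkyl chain in place of that ring, or an amine or a carboxylic acid on it, would produce a step beyond the scatter. The rest of the shared core is the same in all four compounds, which leaves open what a change there would do to the cytotoxicity read-out.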